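The source may report more compounds than this note shows. Statements on the series, on what has been measured and on what is new or still open speak of the compounds shown alone.

Working notes on the series. In an in vitro ADME assay on microsomes (Homo sapiens) for metabolic stability (a lower number here means that the compound disappears faster, a higher number that the compound lasts longer), compound 1 `CCc1nc(NC(CC)CC)c(Cl)nc1-c1ccc(Cl)cc1Cl` gives 0.167 h. Compound 2 `CCc1nc(-c2ccc(OC)cc2O)c(CC)nc1NC(CC)CC` gives 0.3 h, and compound 3 `CCc1nc(-c2ccc(Cl)cc2Cl)c(CC)nc1NC(C1CC1)C1CC1` gives 0.183 h. All three numbers lie within the usual scatter of one another, so compound 1 stands level with both and no order can be read among them. Going by the values given here, no two measured compounds differ in one place only, so no single change has a measured size here.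

Still unmeasured is compound 4 `CCc1nc(NC(CC)CC)c(OC)nc1-c1ccc(Cl)cc1Cl`, which carries methoxy in place of the chloro of compound 1, on an aromatic carbon ortho to a (pentan-3-yl)amino group and para to an ethyl group: methoxy in place of chloro on an aromatic carbon. No step beyond the scatter is expected in this assay, in either direction, since compound 2 at 0.3 h and compound 3 at 0.183 h both stay within the scatter of compound 1 despite their structural differences. The expected step of a 1.2-fold higher number from compound 1 to compound 4 (0.08 log units; within the scatter) is therefore small. For compound 4 the estimated half-life is 0.2 h, with an expected range of 0.1 h to 0.4 h.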

Compound 4, half-life: 0.583 h
For compound 4 the middle estimate is 2.9-fold (0.46 log units) below the measured one; the whole stated range lies below it.
By their numbers in this assay, from the lowest: compounds 1, 3, 2 and 4 (each within the scatter of the next, the first and the last beyond it).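

In this assay, going by these compounds alone, the exchange of chloro for methoxy, on the aromatic carbon next to the ring nitrogen, gives a 3.5-fold higher number from compound 1 to compound 4 (0.54 log units; beyond the scatter) and is the first single change with a measured size. The position ortho to a (pentan-3-yl)amino group and para to an ethyl group therefore bears on the half-life, with the rest of compound 1 held constant. No measurement at hand accounts for this step, so its origin stays unassigned.

Open, from the compounds shown here alone, is whether the step belongs to methoxy alone or would also appear with an amine, a hydroxyl or a longer alkoxy chain such as ethoxy at this position. Also open, going by these compounds, is whether the exchange keeps its size with another amine in place of the (pentan-3-yl)amino group.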